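Swapping chloro for trifluoromethyl on an imidazole propyl ether

The source may hold more compounds than are shown below. What is called first, only, known or untested is meant among the compounds shown, and "the series" means these compounds.

The set comprises two measured compounds and one awaiting measurement. In a functional assay on K562 cells (Homo sapiens) for cytotoxicity (a lower number here means that less compound is tolerated, a higher number that more compound is tolerated), compound 1 `Clc1ccc(OC(CCn2ccnc2)c2ccccc2)cc1` gives 221000 nM, the highest of the two numbers shown. Compound 2 `Cc1ccc(C(CCn2ccnc2)Oc2ccc(Cl)cc2Cl)cc1` gives 31400 nM in this assay, a lower number than that of compound 1, and the gap between them lies beyond the scatter. Within the data shown here, no step between these two is computed, since they differ in more than one place.

Compound 3 `FC(F)(F)c1ccc(OC(CCn2ccnc2)c2ccccc2)cc1` differs from compound 1 by a single change: trifluoromethyl in place of chloro on an aromatic carbon. Among the measured compounds shown here, nothing among the measured compounds shows how this change plays out in this assay. On that basis a modest downward movement is expected, a 1.8-fold lower number from compound 1 to compound 3 (0.27 log units; within the scatter), though a result within the scatter would not surprise. Compound 3 is therefore estimated at 120000 nM in this assay, with a range from 40000 nM to 300000 nM.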

Compound 3, half-maximal cytotoxic concentration: 71000 nM
Compound 3: middle estimate off by 1.7-fold (0.23 log units), on the high side; low and high end bracket the measured number.
By their numbers in this assay, from the lowest: compound 2; then compound 3; then compound 1.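

In this assay, among these compounds, the step of trifluoromethyl in place of chloro on an aromatic carbon, para to a large group, is a 3.1-fold lower number from compound 1 to compound 3 (0.49 log units; beyond the scatter) and is the first single-place comparison in the set. It shows that the number responds to the group at this position, by a step beyond the usual scatter, which compound 1 and compound 2 could not show because they differ in more than one place. No measurement available here explains the shift.

As far as these compounds go, whether a nitrile, a methoxy group or a fluoro group at this same position would move the number in the same direction remains open. Also open, from the compounds shown here alone, is whether the swap would have a similar effect on the core of compound 2, since this change is seen in one pair only.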